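Removing the aromatic fluoro: cytotoxicity of compound 4

This account rests on a few compounds, and the source may have more. Where it says the series, first, only, none or still open, it means among the compounds named here.

Measured compounds:
compound 1, `O=C1N(Cc2ccccc2Br)c2cccn2S(=O)(=O)N1Cc1ccccc1`, 226000 nM
compound 2, `CC(C)=CCN1C(=O)N(Cc2ccccc2)S(=O)(=O)n2cccc21`, 226000 nM
compound 3, `N#CCN1C(=O)N(Cc2cccc(F)c2)S(=O)(=O)n2cccc21`, 172000 nM

In an ADME assay on MT4 cells (Homo sapiens) for cytotoxicity, read by MTT assay, with a stated time of 5 days (a lower number here means that less compound is tolerated, a higher number that more compound is tolerated), compound 1 gives 226000 nM, compound 2 gives 226000 nM, and compound 3 gives 172000 nM. Compound 3 lies within the scatter of both compound 1 and compound 2, so the three numbers do not separate from one another. Within the data shown here, the one step recorded, no change at the digits printed from compound 1 to compound 2 (within the scatter), changes the group on the chain carbon and shows no movement in this assay.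

Compound 4, `N#CCN1C(=O)N(Cc2ccccc2)S(=O)(=O)n2cccc21`, differs from compound 3 by hydrogen in place of fluoro on an aromatic carbon. Among the measured compounds shown here, no measured step touches this position; the only comparison available is that compound 1 and compound 3, which carry different groups on the phenyl ring as well as different chains, sit within the scatter of each other. On that basis no step beyond the scatter is expected, and the step of a 1.2-fold higher number from compound 3 to compound 4 (0.07 log units; within the scatter) is estimated to be small. Compound 4 is therefore expected to give about 200000 nM in this assay, with a range of 120000 nM to 350000 nM.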

Compound 4, half-maximal cytotoxic concentration: 180000 nM
Estimate against measurement, compound 4: 1.1-fold (0.05 log units) above, and the stated range covers the measured number.
By their numbers in this assay, from the lowest: compounds 3, 4, 1 and 2 (each within the scatter of the next).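

In this assay, among these compounds, the change from 3-fluorophenyl to phenyl gives a 1.0-fold higher number from compound 3 to compound 4 (0.02 log units; within the scatter) as the only direct reading at this aromatic carbon, so fluoro and hydrogen do not separate here. With the phenyl ring left bare, the chain position can also be read against the cyano group, which gives a 1.3-fold lower number from compound 2 to compound 4 (0.10 log units; within the scatter) and a 1.3-fold lower number from compound 1 to compound 4 (0.10 log units; within the scatter) and shows that these three groups on the chain carbon do not separate either. No supporting evidence bears on this result.

Going by these compounds, only fluoro and hydrogen are compared directly on this aromatic carbon, so it remains open whether an amine or a carboxylic acid there would give a step beyond the scatter. On these data alone, it also remains open whether a longer chain carrying an amine, in place of the cyano group, would do so.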